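The source may report more compounds than this note shows. Statements on the series, on what has been measured and on what is new or still open speak of the compounds shown alone.

Series notes. Compound 1 `Cc1ccc(C(=O)N/N=C/c2ccccc2)c(O)c1`, compound 2 `Cc1ccc(C(=O)N/N=C/c2ccc(Cl)cc2Cl)c(O)c1` and compound 3 `Cc1ccc(C(=O)N/N=C/c2ccccc2[N+](=O)[O-])c(O)c1` share one core and differ only in the substituents on the aryl ring attached to the hydrazone. In an ADME assay on cells (Mus musculus, strain BALB/C) for cytotoxicity, read by MTT assay, with a stated time of 24 h (on this read-out lower numbers stand for higher toxicity in this test and higher numbers for lower toxicity in this test), compound 1 gives 578000 nM, compound 2 gives 291000 nM and compound 3 gives 644000 nM. Compound 3 therefore holds the highest of the three numbers; compound 1 is nearest, within the scatter, while compound 2 lies furthest, beyond the scatter.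

Among the measured compounds shown here, the one single-point step so far, a 1.1-fold higher number from compound 1 to compound 3 (0.05 log units; within the scatter), shows that placing nitro on the aromatic carbon left the number essentially unchanged.

Compound 4 `Cc1ccc(C(=O)N/N=C/c2ccccc2Cl)c(O)c1` is not yet measured. It differs from compound 3 as follows: chloro in place of nitro on an aromatic carbon.

Bearing on this step: the step from compound 1 to compound 3 was flat, and compound 2, carrying chloro at two positions, gave the lowest number of the three. Removing nitro is thus expected to do little on its own, and the incoming chloro is the only hint of a lower number. Compound 4 is accordingly expected to give a modestly lower number in this assay than compound 3, the step of a 1.4-fold lower number from compound 3 to compound 4 (0.16 log units; within the scatter) being estimated close to or just beyond the scatter. The estimate for compound 4 is 450000 nM, between 250000 nM and 800000 nM.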

Compound 4, half-maximal cytotoxic concentration: 125000 nM
The estimate for compound 4 lay 3.6-fold (0.56 log units) above the measured number, outside the stated range (below it).
By their numbers in this assay, from the lowest: compound 4; then compounds 2, 1 and 3 (each within the scatter of the next, the first and the last beyond it).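

In this assay, among the compounds shown here, the aromatic carbon ortho to a large group turns out to respond strongly to the identity of its substituent: chloro in place of hydrogen there gives a 4.6-fold lower number from compound 1 to compound 4 (0.67 log units; beyond the scatter) while nitro in place of hydrogen had given only a 1.1-fold higher number from compound 1 to compound 3 (0.05 log units; within the scatter) and so the direct exchange of nitro for chloro gives a 5.2-fold lower number from compound 3 to compound 4 (0.71 log units; beyond the scatter) as the largest step so far. The chloro effect also proves not to be a simple matter of adding chloro groups, since hydrogen in place of the second chloro of compound 2 gives a 2.3-fold lower number from compound 2 to compound 4 (0.37 log units; beyond the scatter) and leaves the compound with one chloro holding a lower number than the compound with two. No measurement at hand accounts for why chloro and nitro part so widely at this position.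

Still open, from the compounds shown here alone, is whether a lone chloro on another carbon of the same ring would give a comparable number or whether the step belongs to this position alone. Also open, going by these compounds, is how a methoxy group, an amine or a carboxylic acid at this same place would compare with chloro and nitro in this assay on the shared core.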